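The source may report more compounds than this note shows. Statements on the series, on what has been measured and on what is new or still open speak of the compounds shown alone.

Compound 3, `Cc1ccc(Cn2cnc3c(N(C)C)ncnc32)cc1`, stands at the bottom of the three numbers in a functional assay on the whole organism for inhibition, with Rattus norvegicus as the target, at a dose of 25 mg/kg by the intraperitoneal route (a lower number here means less inhibition, a higher number more inhibition at the dose given (going by the name of the read-out)), where compound 3 gives 0%. It sits level with compound 2, `CN(C)c1ncnc2c1ncn2Cc1ccc(Cl)cc1`, since compound 2 gives 0%, and the two are separated by no change at the digits printed from compound 2 to compound 3 (within the scatter). Within the data shown here, the only number above them comes from compound 1, `CN(C)c1ncnc2c1ncn2Cc1ccc(F)cc1`, for which compound 1 gives 21%; the drops are a number 21 percentage points lower from compound 1 to compound 2 (beyond the scatter) and a number 21 percentage points lower from compound 1 to compound 3 (beyond the scatter).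

Compound 4, `CN(C)c1ncnc2c1ncn2Cc1ccc([N+](=O)[O-])cc1`, differs from compound 3 by nitro in place of methyl on an aromatic carbon. Among the measured compounds shown here, no measured step involves a nitro group, so only the three substitutions at the same position of the ring bear on it: two of them left the read-out unchanged at zero and one, fluoro, reached a modest value. With nothing in the set pointing to a rise beyond that, compound 4 is expected to stay near the low end, with a number 8 percentage points higher from compound 3 to compound 4 (within the scatter) estimated as the step from compound 3. The estimate for compound 4 is therefore 8%, within the range 0% to 30%.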

Compound 4, a percentage reported as inhibition, in the whole organism at one dose (the size of the read-out at that dose, not a potency): 0%
Beside the measured number, compound 4's estimate is 8 percentage points above it; the measured number falls inside the stated range.
By their numbers in this assay, from the lowest: compounds 2, 3 and 4 (each within the scatter of the next); then compound 1.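

In this assay the step from methyl to nitro gives no change at the digits printed from compound 3 to compound 4 (within the scatter) and the step from chloro to nitro gives no change at the digits printed from compound 2 to compound 4 (within the scatter), so three heavy atoms and two hydrogen-bond acceptors in place of one heavy atom and none leave the read-out where it stood. Among these compounds, with a number 21 percentage points lower from compound 1 to compound 4 (beyond the scatter) as a step beyond the scatter, fluoro is now the only one of the four groups on this aromatic carbon, para to a large group, that stands clear of the others. No measured evidence accounts for fluoro standing apart from the other three groups.

The compounds shown leave open whether an amine, a hydroxyl or a methoxy group at this position would join fluoro or the other three. They also leave open how compound 2, compound 3 and compound 4 would compare at a higher dose.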